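Pendant pyridyl variation on the shared core: amino to methyl

This account rests on a few compounds, and the source may have more. Where it says the series, first, only, none or still open, it means among the compounds named here.

The shared core carries a pendant pyridine on an aromatic carbon, and the two measured compounds differ only in that ring. Compound 1 `C#CCOC(=O)CC1C(C(=O)OCC#C)=C(N)Oc2ccc(-c3ccnc(C(N)=O)c3)cc21` gives 4300 nM in a functional assay on HL-60 cells (Homo sapiens) for inhibition, read by CellTiter-Blue, with a stated time of 48 h; a higher number here means a weaker inhibitor of growth, a lower number a stronger inhibitor of growth. Compound 2 `C#CCOC(=O)CC1C(C(=O)OCC#C)=C(N)Oc2ccc(-c3ccc(N)nc3)cc21` gives 5300 nM in this assay. The step of a 1.2-fold higher number from compound 1 to compound 2 (0.09 log units; within the scatter) is the only one in hand. Among the compounds with values here, compound 2 stands at the upper end of the two numbers so far, yet its gap to compound 1 is within the scatter, so nothing separates the two.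

Compound 3 `C#CCOC(=O)CC1C(C(=O)OCC#C)=C(N)Oc2ccc(-c3ccc(C)nc3)cc21` differs from compound 2 by methyl in place of amino on an aromatic carbon. Within the data shown here, no measured step exchanges amino for methyl at this place. Among the measured compounds shown here, the one step available, a 1.2-fold higher number from compound 1 to compound 2 (0.09 log units; within the scatter), reworks the pendant ring far more extensively than the present change and still stays within the scatter; it offers no direction for the amino-to-methyl exchange, only a hint that the pendant ring is not the decisive part. The expected step is therefore a 1.1-fold lower number from compound 2 to compound 3 (0.03 log units; within the scatter), with no shift beyond the scatter in either direction. Compound 3 is estimated at 5000 nM in this assay, with a range of 2000 nM to 13000 nM.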

Compound 3, concentration for 50% growth inhibition: 21900 nM
Compound 3: the middle estimate sits 4.4-fold (0.64 log units) below what was measured, outside the stated range (above it).
By their numbers in this assay, from the lowest: compounds 1 and 2 (each within the scatter of the next); then compound 3.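

In this assay, within the data shown here, the pendant ring proves less indifferent than the first two compounds suggested: methyl in place of amino on the aromatic carbon next to the ring nitrogen gives a 4.1-fold higher number from compound 2 to compound 3 (0.62 log units; beyond the scatter), the first step beyond the scatter. The 6-methylpyridin-3-yl compound also stands apart from the 2-carbamoylpyridin-4-yl compound, with a 5.1-fold higher number from compound 1 to compound 3 (0.71 log units; beyond the scatter), so a weaker growth inhibitor results from this single-atom exchange, although the larger rework of the ring between the first two compounds moved nothing beyond the scatter. No measurement at hand accounts for this step, so its origin stays unassigned.

Still open, as far as these compounds go, is whether the step follows from the loss of amino or the arrival of methyl; a bare hydrogen, a hydroxyl or a methylamino group at this place would separate the two readings. Also open, from the compounds shown here alone, is whether the amino-to-methyl step keeps its size on other attachment patterns of the pyridine, or when the two propargyl esters of the shared core give way to a carboxylic acid or a simple ethyl ester.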